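The source may report more compounds than this note shows. Statements on the series, on what has been measured and on what is new or still open speak of the compounds shown alone.

Two compounds already carry numbers here. Compound 1 `COc1c(/C=C2/C(=O)Nc3ccccc32)c2ccccc2n1-c1ccccc1` is the stronger of the pair: in a functional assay on cells (Melanoma cell, Homo sapiens) for cytotoxicity, with a stated time of 48 h (on this read-out lower numbers stand for stronger inhibition of growth and higher numbers for weaker inhibition of growth), compound 1 gives 1480 nM, while compound 2 `COc1ccc2c(c1)/C(=C\c1c(Cl)n(Cc3cc(OC)c(OC)c(OC)c3)c3cc(C)c(OC)cc13)C(=O)N2` gives 14800 nM in this assay, a gap well beyond the usual scatter. Compound 3 `COc1c(/C=C2/C(=O)Nc3ccc(Cl)cc32)c2ccccc2n1-c1ccccc1` is still unmeasured and differs from compound 1 by one change, (chloro in place of hydrogen on an aromatic carbon). Within the data shown here, no comparable step has been measured, so the expectation rests on compound 1 alone. A step of a 1.2-fold lower number from compound 1 to compound 3 (0.09 log units; within the scatter) is expected, likely no larger than the scatter. Compound 3 is therefore estimated at 1200 nM, within a range from 400 nM to 3500 nM.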

Compound 3, concentration for 50% growth inhibition: 5620 nM
Estimate against measurement, compound 3: 4.7-fold (0.67 log units) below; the whole stated range lies below it.
By their numbers in this assay, from the lowest: compound 1; then compound 3; then compound 2.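

This position on the six-membered aromatic ring of the fused system does not take chloro without cost: in this assay the swap from hydrogen gives a 3.8-fold higher number from compound 1 to compound 3 (0.58 log units; beyond the scatter) and so a modest loss of growth inhibition. A single added atom at this carbon is therefore enough to move the read-out. Nothing measured here accounts for the shift. Going by these compounds, whether a smaller fluoro or an amine at the same carbon would also weaken growth inhibition stays open, as does whether chloro elsewhere on this ring would do the same.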